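From phenyl to 2,4-dimethylphenyl on an amine nitrogen

A few compounds are considered here, and "the series" means these few. Any claim that something is new, unique, unknown or untested is made for them only; others in the source may bear on it.

Measured so far in an ADME assay on Vero cells (Chlorocebus sabaeus) for cytotoxicity, read by luminescence, with a stated time of 2 days; a higher number here means that more compound is tolerated, a lower number that less compound is tolerated 
compound 1 `CCc1nc2ccc(Cl)cc2n1CCCCOc1ccccc1` gives 25 uM
compound 2 `CCc1nc2ccc(C)cc2n1CCCCOc1ccccc1` gives 18 uM
compound 3 `CCc1nc2ccc(C)cc2n1CCCCNc1ccccc1` gives 21 uM

Compound 3, at 21 uM on this scale, lies within the scatter of both compound 1 and compound 2, so these three numbers cannot be told apart. Compound 4 `CCc1nc2ccc(C)cc2n1CCCCNc1ccc(C)cc1C` differs from compound 3 in one place: it carries 2,4-dimethylphenyl in place of phenyl on an amine nitrogen. Two measured steps offer a loose guide. Methyl in place of chloro on an aromatic carbon gave a 1.4-fold lower number from compound 1 to compound 2 (0.14 log units; within the scatter) and anilino in place of phenoxy gave a 1.2-fold higher number from compound 2 to compound 3 (0.07 log units; within the scatter) in the same series. Neither step changes the phenyl group itself, so no direct measure of this change exists yet. In this assay no step beyond the scatter is expected. The estimated step is a 1.2-fold lower number from compound 3 to compound 4 (0.09 log units; within the scatter) and is expected to remain small. For compound 4 the estimate is 17 uM as a middle value, and repeated measurements are expected to fall between 9 uM and 32 uM in most cases.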

Compound 4, half-maximal toxic concentration: 20 uM
The estimate for compound 4 lay 1.2-fold (0.07 log units) below the measured number, and the stated range covers the measured number.
By their numbers in this assay, from the lowest: compounds 2, 4, 3 and 1 (each within the scatter of the next).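

Placing two methyl groups on the phenyl ring, which takes this group from 6 to 8 heavy atoms on the amine nitrogen, gives a 1.1-fold lower number from compound 3 to compound 4 (0.02 log units; within the scatter) in this assay, so this change cannot be told apart from no change at all. Unlike the two earlier steps, which altered the chloro position and the atom joining the chain to the phenyl group, this step alters the phenyl group itself, and it shows that this ring can carry these two methyl groups with no step beyond the scatter. No measurement here offers an explanation for this result.

From the compounds shown here alone, whether a carboxylic acid or an amine on this ring, or a longer chain leading to the amine nitrogen, would move the number beyond the scatter remains open. Going by these compounds, compound 4 also carries both methyl groups at once, so what each does alone remains unknown.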